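This account rests on a few compounds, and the source may have more. Where it says the series, first, only, none or still open, it means among the compounds named here.

Measured compounds:
compound 1 `CN1CCN(C(=S)SCc2ccc3nc(N)nc(N)c3c2)CC1`: 9200 nM in a functional assay on A549 cells (Homo sapiens) for antiproliferative activity, read by MTT assay, with a stated time of 72 h; a higher number here means a weaker inhibitor, a lower number a stronger inhibitor
compound 2 `Nc1nc(N)c2cc(CSC(=S)N3CCN(c4ccc(O)cc4)CC3)ccc2n1`: 4210 nM
compound 3 `COc1ccc(N2CCN(C(=S)SCc3ccc4nc(N)nc(N)c4c3)CC2)cc1`: 1590 nM

Compound 1 stands highest of the three numbers in this assay; compound 2 is nearest and compound 3 furthest, both lower. The two measured steps from compound 1 each replace the methyl on the ring nitrogen with an aryl group: a 2.2-fold lower number from compound 1 to compound 2 (0.34 log units; beyond the scatter) and a 5.8-fold lower number from compound 1 to compound 3 (0.76 log units; beyond the scatter); the further step a 2.6-fold lower number from compound 2 to compound 3 (0.42 log units; beyond the scatter) separates the two aryl cases.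

Compound 4 `Nc1nc(N)c2cc(CSC(=S)N3CCN(c4ncccn4)CC3)ccc2n1` is unmeasured. It differs from compound 1 by pyrimidin-2-yl in place of methyl on an amine nitrogen in a ring. Both aryl replacements bear on this step and both gave modest decreases beyond the scatter, so a modest decrease is expected here as well, a 2.9-fold lower number from compound 1 to compound 4 (0.46 log units; beyond the scatter). Compound 4 is therefore estimated at 3200 nM, with a range of 1300 nM to 8000 nM.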

Compound 4, half-maximal inhibitory concentration: 4010 nM
Compound 4: middle estimate off by 1.3-fold (0.10 log units), on the low side; the measured number falls inside the stated range.
By their numbers in this assay, from the lowest: compound 3; then compounds 4 and 2 (each within the scatter of the next); then compound 1.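

Pyrimidin-2-yl on the ring nitrogen also improves on methyl, a 2.3-fold lower number from compound 1 to compound 4 (0.36 log units; beyond the scatter), so the gain extends beyond the substituted phenyl groups to an aromatic ring with hetero atoms. The change from 4-hydroxyphenyl shows no separable difference, a 1.0-fold lower number from compound 2 to compound 4 (0.02 log units; within the scatter), whereas the change from 4-methoxyphenyl gives up activity, a 2.5-fold higher number from compound 3 to compound 4 (0.40 log units; beyond the scatter), so the aromatic groups are not interchangeable at this nitrogen. No supporting data bear on the origin of these differences.

Open, as far as these compounds go, is whether a cyclohexyl or benzyl group on the same nitrogen would match the aromatic groups. Also open, from the compounds shown here alone, is whether an ethoxy group, with its longer chain, would hold the level of 4-methoxyphenyl.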